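This account rests on a few compounds, and the source may have more. Where it says the series, first, only, none or still open, it means among the compounds named here.

Measured compounds:
- compound 1, `C/C(=C\CC/C(C)=C/CC[C@@H]1[C@@]2(C)CCC(=O)C(C)(C)[C@H]2CC[C@@]1(C)O)CC/C=C(\C)C(=O)OCc1cn(-c2ccc(F)c(Cl)c2)nn1`: 22900 nM
- compound 2, `C#CCOC(=O)/C(C)=C/CC/C(C)=C/CC/C(C)=C/CC[C@@H]1[C@@]2(C)CCC(=O)C(C)(C)[C@H]2CC[C@@]1(C)O`: 18900 nM
- compound 3, `C/C(=C\CC/C(C)=C/CC[C@@H]1[C@@]2(C)CCC(=O)C(C)(C)[C@H]2CC[C@@]1(C)O)CC/C=C(\C)C(=O)OCc1cn(-c2cccc([N+](=O)[O-])c2)nn1`: 24800 nM

In a functional assay on PC-3 cells (Homo sapiens) for antiproliferative activity, read by MTT assay, with a stated time of 48 h (a higher number here means a weaker inhibitor, a lower number a stronger inhibitor), compound 2 gives the lowest of the three numbers, but its gaps to compound 1 and to compound 3 are both within the scatter, so the three esters read as one level. Among the measured compounds shown here, the only measured step within the set, a 1.1-fold higher number from compound 1 to compound 3 (0.03 log units; within the scatter), concerns the aryl group on the triazole and is also within the scatter.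

Compound 4, `C/C(=C\CC/C(C)=C/CC[C@@H]1[C@@]2(C)CCC(=O)C(C)(C)[C@H]2CC[C@@]1(C)O)CC/C=C(\C)C(=O)O`, has not been measured. It differs from compound 2 by hydrogen in place of propargyl on an oxygen next to a carbonyl group, that is, the propargyloxycarbonyl becomes a carboxy. For the measured compounds named here, no measured step touches the ester oxygen; the series so far only varies the group carried on that oxygen among esters, with no effect beyond the scatter. Whether the free acid departs from the ester level cannot be read from these numbers, so no direction is expected with confidence, and the estimate is kept near the measured level with a wide range.

Compound 4 is expected to give about 25000 nM in this assay, between 10000 nM and 60000 nM. The estimated step of a 1.3-fold higher number from compound 2 to compound 4 (0.12 log units; within the scatter) is therefore expected to stay within or close to the scatter.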

Compound 4, half-maximal inhibitory concentration: 40700 nM
The estimate for compound 4 lay 1.6-fold (0.21 log units) below the measured number, and the stated range covers the measured number.
By their numbers in this assay, from the lowest: compounds 2, 1, 3 and 4 (each within the scatter of the next, the first and the last beyond it).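

In this assay, among the compounds shown here, hydrogen in place of propargyl on an oxygen next to a carbonyl group gives a 2.2-fold higher number from compound 2 to compound 4 (0.33 log units; beyond the scatter) as the first step beyond the scatter, though only a modest one. For the compounds shown here, the earlier step changed the aryl group on the triazole and stayed within the scatter, so this result is the first sign that the read-out responds to a change at this oxygen, with propargyloxycarbonyl giving way to carboxy. No measurement shown here accounts for the shift.

Still open, on these data alone, is whether a methyl ester or a primary amide at this place would stay level with compound 2 or move towards compound 4. A single pair also leaves open whether the same step would appear with the aryl triazole esters as the starting point.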